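Halogenated Anilide Replaces the Tolyl Group on a Shared Core

The source may report more compounds than this note shows. Statements on the series, on what has been measured and on what is new or still open speak of the compounds shown alone.

Compound 1 `Cc1ccc(NC(=O)COc2ccc3cc(/C=C4/SC(=O)NC4=O)ccc3c2)cc1` was tested in an assay on isolated protein for inhibition of histone deacetylase 8 (Homo sapiens), with a stated time of 1 h (on this read-out higher numbers stand for weaker inhibition and lower numbers for stronger inhibition), and gave 9000 nM. Among the two numbers shown, compound 1 holds the highest; its nearest neighbour is compound 3 `O=C(COc1ccc2cc(/C=C3/SC(=O)NC3=O)ccc2c1)Nc1ccccc1`, which in this assay gives 4500 nM, and the step of a 2.0-fold lower number from compound 1 to compound 3 (0.30 log units; within the scatter) stays within the scatter. Compound 2 `O=C(COc1ccc2cc(/C=C3/SC(=O)NC3=O)ccc2c1)Nc1ccc(Br)cc1F` gives > 50000 nM in this assay, which is a limit and not a number, namely (the limit of > 50000 nM in this assay, at which 1 of the 3 values shown sits). The step of an at least 5.5-fold higher number from compound 1 to compound 2 (0.74 log units; beyond the scatter) and the step of an at least 11-fold lower number from compound 2 to compound 3 (1.04 log units; beyond the scatter) both show that a bromine- and fluorine-bearing phenyl on the amide-type nitrogen raises the number well beyond the scatter. Compound 4 `O=C(COc1ccc2cc(/C=C3/SC(=O)NC3=O)ccc2c1)Nc1c(F)cc(F)cc1Br` differs from compound 1 by 2-bromo-4,6-difluorophenyl in place of 4-methylphenyl on an amide-type nitrogen. That change again places a bromine- and fluorine-bearing phenyl on the amide-type nitrogen, so a weakening like the one seen in an at least 5.5-fold higher number from compound 1 to compound 2 (0.74 log units; beyond the scatter) is expected. Compound 4 is therefore expected to give about 50000 nM, within a range from 15000 nM to 200000 nM, and quite possibly only a limit. This would be an expected step of a 5.6-fold higher number from compound 1 to compound 4 (0.74 log units; beyond the scatter), lying beyond the scatter.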

Compound 4, half-maximal inhibitory concentration: > 50000 nM
Compound 4: no number, only a limit; the forecaster's own chance of this, stated with the estimate: 60%; the middle value lies on the limit itself.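

Placing 2-bromo-4,6-difluorophenyl on the amide-type nitrogen again weakens inhibition, seen as an at least 5.5-fold higher number from compound 1 to compound 4 (0.74 log units; beyond the scatter) and as an at least 11-fold higher number from compound 3 to compound 4 (1.04 log units; beyond the scatter), so among the compounds shown the loss is not confined to the 4-bromo-2-fluorophenyl of compound 2. In this assay compound 4 gives > 50000 nM, which is a limit and not a number. The step from compound 2 to compound 4 cannot be read, since both values are limits: the limit of > 50000 nM in this assay, at which 2 of the 4 values shown sit.

From the compounds shown here alone, whether bromine alone or fluorine alone on the phenyl would raise the number remains open, as does how far compound 2 and compound 4 lie past their limits. Going by these compounds, the effect of a 4-methoxyphenyl, a 4-aminophenyl or a pyridyl group on the amide-type nitrogen also remains open.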